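The compounds below may be only part of what the source reports. "The series", "measured", "known", "first", "only" and "open" are said of these compounds alone.

Compound 1, `CCCCCCOc1ccc(-n2cnnc2CCCC)cc1`, is the reference point of this account. In a functional assay on the whole organism (strain C57B/6) with Mus musculus as the target, in the maximal electroshock model (on this read-out lower numbers stand for an effect already at smaller amounts and higher numbers for an effect only at larger amounts of compound), compound 1 gives 13.6 mg/kg, the lowest of the two numbers obtained among the measured compounds. Its nearest neighbour is compound 3, `CCCCCCOc1ccc(-n2cnnc2-c2ccc(F)cc2)cc1`, which in this assay gives 22 mg/kg; the step of a 1.6-fold higher number from compound 1 to compound 3 (0.21 log units; within the scatter). Compound 2, `CCCCCCCCCc1nncn1-c1ccc(OCCCCCC)cc1`, in this assay gives only the limit > 40 mg/kg, not a number. As far as these compounds go, the step of an at least 2.9-fold higher number from compound 1 to compound 2 (0.46 log units; beyond the scatter) is read against (the limit of > 40 mg/kg in this assay, at which 1 of the 3 values shown sits), so its true size remains open.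

Compound 4, `CCCCCCOc1ccc(-n2cnnc2Cc2ccccc2)cc1`, has not yet been measured. It differs from compound 1 in one place: phenyl in place of propyl on a saturated chain carbon bound to an aromatic carbon. Both measured steps bear on this change in part. The exchange of butyl for 4-fluorophenyl on the aromatic carbon stayed within the scatter, whereas the lengthening of the saturated chain moved the value at least modestly toward larger amounts. Compound 4 keeps a short chain and adds an aromatic ring, so in this assay the expected step is small, at most modest, and if anything toward a higher number. The expected step is a 1.3-fold higher number from compound 1 to compound 4 (0.12 log units; within the scatter). Compound 4 is therefore estimated at 18 mg/kg, with a range from 9 mg/kg to 40 mg/kg.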

Compound 4, dose for half-maximal effect: 19 mg/kg
Estimate against measurement, compound 4: 1.1-fold (0.02 log units) below; the measured number falls inside the stated range.
By their numbers in this assay, from the lowest: compounds 1, 4 and 3 (each within the scatter of the next). At a limit, above all of these: compound 2.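

In this assay, the change from butyl to benzyl, with phenyl in place of propyl on a saturated chain carbon bound to an aromatic carbon, gives a 1.4-fold higher number from compound 1 to compound 4 (0.15 log units; within the scatter), so an aromatic ring carried on this chain carbon leaves the read-out within the scatter of the butyl compound. For the compounds shown here, the second ring-bearing group behaves no differently, since the exchange of 4-fluorophenyl for benzyl gives a 1.2-fold lower number from compound 3 to compound 4 (0.06 log units; within the scatter), and among the four compounds only the one with the nonyl chain stands apart. Set against that nonyl chain, benzyl gives an at least 2.1-fold lower number from compound 2 to compound 4 (0.32 log units; beyond the scatter), a step whose true size stays open, as one end of it is a limit and not a number: the limit of > 40 mg/kg in this assay, at which 1 of the 4 values shown sits.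

The compounds shown do not tell what an amine or a carboxylic acid would do at this place, either directly on the core or on the phenyl of the benzyl group. They also leave open at what length, between butyl and nonyl, a longer chain such as hexyl would begin to move the number in this assay.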